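This account rests on a few compounds, and the source may have more. Where it says the series, first, only, none or still open, it means among the compounds named here.

In an ADME assay on HepG2 cells (Homo sapiens) for cytotoxicity, read by MTT assay, with a stated time of 48 h (a lower number here means a stronger inhibitor, a higher number a weaker inhibitor), compound 3 `CC(C)CN1C(=O)/C(=C/c2ccccn2)S/C1=N\c1ccccc1` gives > 100000 nM, which is a limit of the assay and not a number. Compound 1 `CC(C)CN1C(=O)/C(=C/c2ccc([N+](=O)[O-])cc2)S/C1=N\c1ccccc1` gives > 100000 nM, which is also a limit. For compound 2 `CC(C)CN1C(=O)/C(=C/c2ccc(O)cc2)S/C1=N\c1ccccc1` the entry is "not determined" (no result reported). Within the data shown here, the only measured step, a step that the two limits leave unreadable from compound 1 to compound 3, gives no usable size, so the sole guide is the limit of > 100000 nM in this assay, at which 2 of the 3 values shown sit. Compound 4 `CC(C)CN1C(=O)/C(=C/c2cccc(Cl)c2)S/C1=N\c1ccccc1` differs from compound 3 at one place: 3-chlorophenyl in place of pyridin-2-yl on a double-bonded chain carbon bound to a double-bonded ring carbon. It carries 3-chlorophenyl in place of pyridin-2-yl on a double-bonded chain carbon bound to a double-bonded ring carbon. No change beyond the scatter is expected in this assay, and the estimated step is a number no higher from compound 3 to compound 4 (the limit leaves the size open). Compound 4 is expected at 100000 nM, with an estimated range of 30000 nM to 300000 nM.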

Compound 4, half-maximal inhibitory concentration: 88100 nM
Beside the measured number, compound 4's estimate is 1.1-fold (0.06 log units) above it; the measured number falls inside the stated range.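

In this assay compound 4 gives 88100 nM, the first actual number rather than a limit for a group on this double-bonded chain carbon. With an at least 1.1-fold lower number from compound 3 to compound 4 (0.05 log units; that floor lies within the scatter) and an at least 1.1-fold lower number from compound 1 to compound 4 (0.05 log units; that floor lies within the scatter), 3-chlorophenyl is not shown to differ beyond the scatter from pyridin-2-yl or 4-nitrophenyl. Limits still make up half of the readings: the limit of > 100000 nM in this assay, at which 2 of the 4 values shown sit. From the compounds shown here alone, the true size of both steps stays open. Also open, going by these compounds, is whether an amine or a carboxylic acid in place of 3-chlorophenyl would move the number beyond the scatter.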